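The source may report more compounds than this note shows. Statements on the series, on what has been measured and on what is new or still open speak of the compounds shown alone.

Measured so far in an ADME assay on the whole organism with Oryza sativa as the target, tested at 10 uM; on this read-out higher numbers stand for a weaker effect at the one concentration tested and lower numbers for a stronger effect:

compound 1 `Cc1cccc(NC(=O)N[C@@H](C)c2ccccc2)c1`: 100%
compound 2 `CC(=O)c1cccc(NC(=O)N[C@@H](C)c2ccccc2)c1`: 94%
compound 3 `C[C@@H](NC(=O)Nc1cccc(Br)c1)c1ccccc1`: 99%

All three numbers sit close together. Compound 3 lies within the scatter of the other two: compound 1 gives 100% and compound 2 gives 94%, so no order among the three can be read from these values.

Within the data shown here, the only step between measured compounds is a number 6 percentage points lower from compound 1 to compound 2 (within the scatter), which concerns a substituent on an aromatic carbon and does not touch configuration.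

Compound 4 `C[C@H](NC(=O)Nc1cccc(Br)c1)c1ccccc1` is not yet measured. Its relation to compound 3: the two compounds have the same atoms and bonds and differ only in configuration as drawn: 1 of 1 stereo elements differ; a stereocentre at a saturated chain carbon is drawn R in compound 3 and S in compound 4. Among the measured compounds shown here, no measured pair changes only a stereocentre, so there is no step that bears directly on this change; the one measured step, a number 6 percentage points lower from compound 1 to compound 2 (within the scatter), stayed within the scatter, and all three values cluster at the same level.

On that basis the step of a number 1 percentage points lower from compound 3 to compound 4 (within the scatter) is expected to stay within the scatter. Compound 4 is therefore estimated at 98%, with a range of 88% to 100%.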

Compound 4, a percentage reported as activity, at one concentration (the size of the read-out at that concentration, not a potency): 99%
Compound 4: middle estimate off by 1 percentage points, on the low side, within the range that was stated.
By their numbers in this assay, from the lowest: compounds 2, 3, 4 and 1 (each within the scatter of the next).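

The stereocentre at the saturated chain carbon gets its first direct test in this assay and the result reads no change at the digits printed from compound 3 to compound 4 (within the scatter) so the drawn configuration does not separate this bromo pair at the one concentration tested. The same compound also links bromo to the earlier substituents on the aromatic carbon: bromo in place of acetyl reads a number 5 percentage points higher from compound 2 to compound 4 (within the scatter) and bromo in place of methyl reads a number 1 percentage points lower from compound 1 to compound 4 (within the scatter) so neither swap moves the read-out beyond the scatter. This pair isolates configuration and nothing else: the fact that compounds 3 and 4 differ only in the configuration as drawn.

From the compounds shown here alone, whether the stereocentre behaves the same way with methyl or acetyl in place of bromo stays open. Going by these compounds, it is also open whether an amine, a carboxylic acid or a longer chain on the aromatic carbon would move the read-out at all.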